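The source may hold more compounds than are shown below. What is called first, only, known or untested is meant among the compounds shown, and "the series" means these compounds.

Measured so far:
compound 1 `COc1ccc(-c2csc(NC(=O)COc3ccc(C(=O)c4ccccc4)cc3C)n2)cc1` gives 27100 nM in a functional assay on Ehrlich cells (Mus musculus) for cytotoxicity, read by trypan blue exclusion, with a stated time of 48 h; on this read-out lower numbers stand for stronger inhibition and higher numbers for weaker inhibition
compound 2 `COc1ccc(-c2csc(NC(=O)COc3ccc(C(=O)c4cccc(Br)c4)cc3C)n2)cc1` gives 38100 nM in this assay

Compound 2 has the higher of the two numbers, but only slightly: a 1.4-fold higher number from compound 1 to compound 2 (0.15 log units; within the scatter), a step that lies within the scatter of repeated measurements, so the two compounds cannot be told apart on these data. Compound 3 `COc1ccc(-c2csc(NC(=O)COc3ccc(C(=O)c4cccc(F)c4)cc3C)n2)cc1` has not been measured. It differs from compound 2 in one place: fluoro in place of bromo on an aromatic carbon. For the measured compounds named here, the only measured step that bears on this position is a 1.4-fold higher number from compound 1 to compound 2 (0.15 log units; within the scatter), in which bromo entered in place of hydrogen at this same aromatic carbon and changed the number by less than the scatter. Going by the values given here, since the one halogen swap seen here moved the number so little, the exchange of bromo for fluoro is expected to give a step of a 1.2-fold lower number from compound 2 to compound 3 (0.09 log units; within the scatter), which is no step beyond the scatter. Compound 3 is therefore estimated at 31000 nM, with a range from 15000 nM to 65000 nM.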

Compound 3, half-maximal inhibitory concentration: 29500 nM
Estimate against measurement, compound 3: 1.1-fold (0.02 log units) above; the range from low to high includes it.
By their numbers in this assay, from the lowest: compounds 1, 3 and 2 (each within the scatter of the next).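

Putting fluoro in place of bromo gives a 1.3-fold lower number from compound 2 to compound 3 (0.11 log units; within the scatter), so these two halogens cannot be told apart at this aromatic carbon in this assay. Fluoro in place of hydrogen gives a 1.1-fold higher number from compound 1 to compound 3 (0.04 log units; within the scatter), so compound 1, compound 2 and compound 3 all lie within the scatter of one another, and the earlier finding for bromo now holds for a second halogen as well. No supporting evidence is available to explain why these exchanges leave the number so little changed.

The compounds shown leave open whether a group other than a halogen, such as an amine, a carboxylic acid or a longer carbon chain, would move the number beyond the scatter at this carbon. They also leave open whether fluoro or bromo on another carbon of this ring would give the same result.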